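Swapping the side chain on the ring nitrogen

The compounds below may be only part of what the source reports. "The series", "measured", "known", "first", "only" and "open" are said of these compounds alone.

Compound 1 `O=S1(=O)CC(Nc2nonc2/C(=N/O)Nc2ccc(F)c(Br)c2)C1` gives 99 nM in an assay on isolated protein for inhibition of Indoleamine 2,3-dioxygenase 1 (Homo sapiens), read by fluorescence, with a stated time of 60 min; on this read-out higher numbers stand for weaker inhibition and lower numbers for stronger inhibition.
Compound 2 `CCNS(=O)(=O)CCNc1nonc1/C(=N/O)Nc1ccc(F)c(Br)c1` gives 95 nM in this assay.

Compound 2 sits within the scatter of compound 1, as the step of a 1.0-fold lower number from compound 1 to compound 2 (0.02 log units; within the scatter) shows, so the two numbers cannot be told apart. Compound 3 `NS(=O)(=O)CCONc1nonc1/C(=N/O)Nc1ccc(F)c(Br)c1` carries 2-sulfamoylethoxy in place of 2-(ethylsulfamoyl)ethyl on a nitrogen on an aromatic ring. For the measured compounds named here, the only measured step at this position, a 1.0-fold lower number from compound 1 to compound 2 (0.02 log units; within the scatter), exchanged one side chain for another without moving the number beyond the scatter. For compound 3 a step of similar smallness, in no clear direction, is therefore expected: a 1.2-fold higher number from compound 2 to compound 3 (0.06 log units; within the scatter). Compound 3 is estimated at 110 nM, within a range from 40 nM to 320 nM.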

Compound 3, half-maximal inhibitory concentration: 87 nM
For compound 3 the middle estimate is 1.3-fold (0.10 log units) above the measured one; the range from low to high includes it.
By their numbers in this assay, from the lowest: compounds 3, 2 and 1 (each within the scatter of the next).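

In this assay, exchanging 2-(ethylsulfamoyl)ethyl for 2-sulfamoylethoxy on a nitrogen on an aromatic ring gives a 1.1-fold lower number from compound 2 to compound 3 (0.04 log units; within the scatter), and exchanging the ring-bearing side chain for this same open chain gives a 1.1-fold lower number from compound 1 to compound 3 (0.06 log units; within the scatter). Three different side chains at this position now give numbers within the scatter of one another, so neither change separates them. No available evidence explains this flat result.

The compounds shown leave open whether a side chain ending in an amine or a carboxylic acid, or a longer chain, would move the number beyond the scatter.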